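Methoxy Added to a Weak Growth Inhibitor

A few compounds are considered here, and "the series" means these few. Any claim that something is new, unique, unknown or untested is made for them only; others in the source may bear on it.

Compound 1 `CO/N=C(\C)COc1ccc2c(=O)cc(-c3ccccc3)oc2c1` gives 2000000 nM in a functional assay on SK-HEP1 cells (Homo sapiens) for antiproliferative activity; on this read-out higher numbers stand for weaker inhibition of growth and lower numbers for stronger inhibition of growth.
Compound 2 `CO/N=C(\C)COc1ccc2c(=O)c(-c3ccccc3)coc2c1` gives 6400000 nM in this assay.
Compound 3 `O=c1cc(-c2ccccc2)oc2cc(OC/C(=N/O)c3ccccc3)ccc12` gives 2000000 nM in this assay.

Compound 3 stands level with compound 1 at the digits shown; together they hold the lowest of the three numbers, and compound 2 gives a higher one. Only one single-place step is known among these: no change at the digits printed from compound 1 to compound 3 (within the scatter), where a larger ring-bearing group replaced a small chain group on the saturated carbon bound to the ring oxygen, and the number did not move beyond the scatter.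

Compound 4 `COc1ccc(/C(COc2ccc3c(=O)cc(-c4ccccc4)oc3c2)=N\O)cc1` differs from compound 3 by methoxy in place of hydrogen on an aromatic carbon. Among the compounds with values here, no measured step alters this aromatic ring, so the known step bears on it only loosely, and it showed no change. With nothing pointing either way, the step is estimated at no change at the digits printed from compound 3 to compound 4 (within the scatter), within the scatter. Compound 4 is thus estimated at 2000000 nM, with a range from 700000 nM to 6000000 nM.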

Compound 4, concentration for 50% growth inhibition: 5600000 nM
Estimate against measurement, compound 4: 2.8-fold (0.45 log units) below; measured number inside the range.
By their numbers in this assay, from the lowest: compounds 1 and 3 (each within the scatter of the next); then compounds 4 and 2 (each within the scatter of the next).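

Within the data shown here, until now the only single-place step, no change at the digits printed from compound 1 to compound 3 (within the scatter), had left the number unmoved, so nothing showed how a change on the new phenyl ring would read. In this assay, phenyl to 4-methoxyphenyl gives a 2.8-fold higher number from compound 3 to compound 4 (0.45 log units; beyond the scatter), so adding a small group to this ring does register, though modestly, and in the direction of weaker inhibition of growth. Nothing available speaks to the reason for this shift.

On these data alone, whether this shift belongs to methoxy itself or would follow any group on this aromatic carbon stays open; a hydroxyl, a fluorine or an amine in the same place would help to separate the two. As far as these compounds go, it is also open whether the same change would read alike on the core of compound 2.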